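A few compounds are considered here, and "the series" means these few. Any claim that something is new, unique, unknown or untested is made for them only; others in the source may bear on it.

In a functional assay on ileum (Cavia porcellus) for inhibition, with a stated time of 30 min (a higher number here means a weaker inhibitor, a lower number a stronger inhibitor), compound 1 (`CC1=CSC(OC(C)C)(c2ccccc2)c2noc(=O)n21`) gives 4820 nM and compound 2 (`COc1cccc(C2(OCC(F)(F)F)SC=C(C)n3c2noc3=O)c1`) gives 12400 nM as the higher of the two numbers, a gap beyond the scatter. Next comes compound 3 (`COc1cccc(C2(OC(C)C)SC=C(C)n3c2noc3=O)c1`), reached from compound 2 by isopropyl in place of 2,2,2-trifluoroethyl on an oxygen on a saturated carbon with isopropyl in place of 2,2,2-trifluoroethyl on an oxygen on a saturated carbon. Going by the values given here, no pair of measured compounds differs in one place only, so no measured step covers this change. Among the compounds with values here, the only guide is compound 1, which also carries isopropyl on an oxygen on a saturated carbon and gives 4820 nM as the lower number. A move toward that number is expected, with a 2.5-fold lower number from compound 2 to compound 3 (0.39 log units; beyond the scatter) as the estimated step, modest but probably beyond the scatter. For compound 3 the estimated value is 5000 nM with an expected range from 1800 nM to 14000 nM as a working figure.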

Compound 3, half-maximal inhibitory concentration: 3530 nM
Beside the measured number, compound 3's estimate is 1.4-fold (0.15 log units) above it; the range from low to high includes it.
By their numbers in this assay, from the lowest: compounds 3 and 1 (each within the scatter of the next); then compound 2.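

In this assay, going by these compounds alone, the swap on the oxygen on a saturated carbon now has a clean reading: isopropyl in place of 2,2,2-trifluoroethyl gives a 3.5-fold lower number from compound 2 to compound 3 (0.55 log units; beyond the scatter), the first single-place comparison at this position. The methoxy in place of hydrogen on an aromatic carbon, with isopropoxy held constant, gives a 1.4-fold lower number from compound 1 to compound 3 (0.14 log units; within the scatter), so this change does not separate the two compounds, and the gap between compound 1 and compound 2 follows the oxygen substituent rather than the methoxy. Nothing measured on these compounds accounts for the step at the oxygen.

Still open, from the compounds shown here alone, is how a longer chain such as n-butyl, or a ring such as cyclopentyl, would read on this oxygen. Also open, going by these compounds, is whether a chlorine or a hydroxyl in place of the methoxy would stay level with compound 3.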